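The source may hold more compounds than are shown below. What is called first, only, known or untested is meant among the compounds shown, and "the series" means these compounds.

Among the compounds with values here, in a functional assay on HOS-TE85 cells (Homo sapiens) for inhibition, read by CCK-8 assay, with a stated time of 72 h, tested at 1 uM (a higher number here means more inhibition at the concentration tested (going by the name of the read-out), a lower number less inhibition), compound 2 `COc1ccc(F)cc1N1C(=O)CSC1c1cccc(C(=O)NCCCCc2ccccc2)c1` gives 95%, the higher of the two numbers known here; compound 1 `COc1ccc(OC)c(N2C(=O)CSC2c2cccc(C(=O)NCCCCc3ccccc3)c2)c1` gives 20%, and the step of a number 75 percentage points higher from compound 1 to compound 2 (beyond the scatter) is the only measured one. Compound 3 `COc1c(F)cccc1N1C(=O)CSC1c1cccc(C(=O)NCCCCc2ccccc2)c1` differs from compound 2 by 3-fluoro-2-methoxyphenyl in place of 5-fluoro-2-methoxyphenyl on an amide-type nitrogen in a ring. Within the data shown here, no measured step moves a fluorine from one ring carbon to another, so that step gives no direct guide to the size or direction of the change. Compound 3 is therefore expected to show a number 35 percentage points lower from compound 2 to compound 3 (beyond the scatter) in this assay, a loose guess, with compound 3 estimated at 60% within a range from 20% to 95%.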

Compound 3, a percentage reported as inhibition, at one concentration (the size of the read-out at that concentration, not a potency): 12%
Beside the measured number, compound 3's estimate is 48 percentage points above it; the whole stated range lies above it.
By their numbers in this assay, from the lowest: compounds 3 and 1 (each within the scatter of the next); then compound 2.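

Moving the fluorine, with the same atoms kept, sharply lowers the read-out in this assay (a number 83 percentage points lower from compound 2 to compound 3 (beyond the scatter)). The high inhibition therefore depends on where the fluorine sits on this ring, and a fluorine as such does not suffice: the 3-fluoro-2-methoxyphenyl and 2,5-dimethoxyphenyl compounds cannot be told apart (a number 8 percentage points lower from compound 1 to compound 3 (within the scatter)). Nothing given here explains the difference. Whether the high value is particular to fluorine stays open, since a chloro or methyl group in that fluorine's place is not among the compounds shown. As far as these compounds go, the part played by the methoxy group also remains open.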